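The source may hold more compounds than are shown below. What is called first, only, known or untested is meant among the compounds shown, and "the series" means these compounds.

Of the compounds shown here, three sharing one core have been measured in a functional assay on MCF7 cells (Homo sapiens) for antiproliferative activity, read by MTT assay, with a stated time of 72 h; on this read-out higher numbers stand for weaker inhibition and lower numbers for stronger inhibition. Compound 1 `COc1ncc(-c2ccc3c(c2)N(c2ccc(C)cc2)C(=O)CO3)cc1NS(=O)(=O)c1ccc(F)cc1` gives 15400 nM. Compound 2 `Cc1ccc(N2C(=O)COc3ccc(-c4cnc(Cl)c(NS(=O)(=O)c5ccc(F)cc5)c4)cc32)cc1` gives 32600 nM, and compound 3 `COc1ccc(N2C(=O)COc3ccc(-c4cnc(OC)c(NS(=O)(=O)c5ccc(F)cc5)c4)cc32)cc1` gives 8260 nM.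

The change from compound 1 to compound 2 is chloro in place of methoxy on an aromatic carbon, and it brought a 2.1-fold higher number from compound 1 to compound 2 (0.33 log units; beyond the scatter). The cores of compound 1 and compound 3 differ by methoxy in place of methyl on an aromatic carbon, a change that went with a 1.9-fold lower number from compound 1 to compound 3 (0.27 log units; within the scatter); compound 3 and compound 1 therefore cannot be ordered against each other. Compound 3 holds the lowest of the three numbers, and its distance from compound 2 is the only one of its two gaps that lies beyond the scatter.

Compound 4 `COc1ncc(-c2ccc3c(c2)N(c2ccc(Cl)cc2)C(=O)CO3)cc1NS(=O)(=O)c1ccc(F)cc1` has not yet been measured. It differs from compound 3 by chloro in place of methoxy on an aromatic carbon. Within the data shown here, this is the same kind of change as the one from compound 1 to compound 2, but not the same: there the place was on a six-membered aromatic ring with one nitrogen, next to the ring nitrogen and ortho to a ((4-fluorophenyl)sulfonyl)amino group, whereas here it sits on a six-membered aromatic ring of carbon only, para to a large group.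

The expectation for compound 4 rests on compound 2, since a 2.1-fold higher number from compound 1 to compound 2 (0.33 log units; beyond the scatter) was a modest step upward in number. A step of similar size, weakened somewhat for the different place, is estimated as a 1.7-fold higher number from compound 3 to compound 4 (0.23 log units; within the scatter). Compound 4 is accordingly expected to give about 14000 nM, most likely between 6000 nM and 35000 nM.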

Compound 4, half-maximal inhibitory concentration: 27600 nM
For compound 4 the middle estimate is 2.0-fold (0.29 log units) below the measured one; measured number inside the range.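

In this assay, chloro in place of methoxy went with a higher number on both cores, and the new step, a 3.3-fold higher number from compound 3 to compound 4 (0.52 log units; beyond the scatter), cannot be told apart in size from the earlier one: the same change on two cores in this assay, a 2.1-fold higher number (0.33 log units; beyond the scatter) from compound 1 to compound 2 and a 3.3-fold higher number (0.52 log units; beyond the scatter) from compound 3 to compound 4, 1.6-fold (0.20 log units) apart, within the scatter of two such steps. On these two cores, then, the change carried over in direction and, within the scatter, in size, although it stood in a different place on each, once on a ring with one nitrogen and once on a six-membered aromatic ring of carbon only. This rests on two pairs alone and shows nothing about other cores or other places, and it gives no ranking of chloro against methyl, since a 1.8-fold higher number from compound 1 to compound 4 (0.25 log units; within the scatter) leaves those two compounds unordered.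

The compounds shown leave open what an amine, a hydroxyl group or a carboxylic acid would give in place of the methoxy on the ring of carbon only, where only methoxy, methyl and chloro appear. They also leave open whether the step would hold on a core where the 4-fluorophenyl group of the sulfonamide is replaced by a plain phenyl or a longer alkyl chain.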